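A few compounds are considered here, and "the series" means these few. Any claim that something is new, unique, unknown or untested is made for them only; others in the source may bear on it.

Working notes on the series, assessed in an assay on adrenal medulla for inhibition of Vasopressin V2 receptor (Rattus norvegicus), read by radioligand binding; on this read-out lower numbers stand for stronger inhibition and higher numbers for weaker inhibition.

Compound 1 `CN(C)C1CCN(C(=O)CCCOc2cc(C(=O)N3CCCCc4sccc43)ccc2NC(=O)c2ccccc2-c2ccccc2)CC1` gives 3 nM. Compound 2 `CN1CCN(C(=O)CCCOc2cc(C(=O)N3CCCCc4sccc43)ccc2NC(=O)c2ccccc2-c2ccccc2)CC1` gives 1 nM. Compound 3 `CN1CCN(CCCCOc2cc(C(=O)N3CCCCc4sccc43)ccc2NC(=O)c2ccccc2-c2ccccc2)CC1` gives 7 nM. On these three numbers compound 2 stands lowest: a 3.0-fold lower number from compound 1 to compound 2 (0.48 log units; beyond the scatter) and a 7.0-fold higher number from compound 2 to compound 3 (0.85 log units; beyond the scatter), both steps beyond the scatter. Compound 1 and compound 3 differ by a 2.3-fold higher number from compound 1 to compound 3 (0.37 log units; beyond the scatter).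

Compound 4 `O=C(Nc1ccc(C(=O)N2CCCCc3sccc32)cc1OCCCC(=O)N1CCC(N2CCCCC2)CC1)c1ccccc1-c1ccccc1` is not yet measured. Relative to compound 2 the change is 4-(piperidin-1-yl)piperidin-1-yl in place of 4-methylpiperazin-1-yl on a carbonyl carbon. The shared core and the chain carrying the carbonyl are unchanged.

Going by the values given here, only one measured step touches the group on that carbonyl carbon: a 3.0-fold lower number from compound 1 to compound 2 (0.48 log units; beyond the scatter), a modest step in which 4-(dimethylamino)piperidin-1-yl gave way to 4-methylpiperazin-1-yl. Compound 4 reverses the direction of that step, returning to a piperidinyl carrying a further amine, here a piperidin-1-yl rather than a dimethylamino. By analogy a modest rise in this assay is expected, on the order of the step from compound 2 back towards compound 1, estimated as a 3.0-fold higher number from compound 2 to compound 4 (0.48 log units; beyond the scatter). The value for compound 4 is therefore estimated at 3 nM, with a range from 1 nM to 9 nM.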

Compound 4, half-maximal inhibitory concentration: 20 nM
Beside the measured number, compound 4's estimate is 6.7-fold (0.82 log units) below it; the whole stated range lies below it.
By their numbers in this assay, from the lowest: compound 2; then compound 1; then compound 3; then compound 4.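

In this assay, going by these compounds alone, the group on the carbonyl carbon proves more sensitive than the earlier compounds showed: 4-(piperidin-1-yl)piperidin-1-yl in place of 4-methylpiperazin-1-yl gives a 20-fold higher number from compound 2 to compound 4 (1.30 log units; beyond the scatter), the only large step so far. The terminal amine on the piperidine ring also matters, since piperidin-1-yl in place of dimethylamino on a saturated ring carbon gives a 6.7-fold higher number from compound 1 to compound 4 (0.82 log units; beyond the scatter), so these two groups are not interchangeable here. No measurement at hand accounts for either step.

Going by these compounds, whether pyrrolidin-1-yl or morpholin-4-yl at that ring carbon would keep the number closer to that of compound 1 remains open. Also open, on these data alone, is whether (4-(piperidin-1-yl)piperidin-1-yl)methyl in place of the carbonyl form would shift the number in the same direction as a 7.0-fold higher number from compound 2 to compound 3 (0.85 log units; beyond the scatter).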